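Ring Amides on a Shared Core: Will a Third Stay Inactive?

The source may hold more compounds than are shown below. What is called first, only, known or untested is meant among the compounds shown, and "the series" means these compounds.

Compound 1 `CCN1CCc2nc(C#Cc3ccccc3)sc2C1` gives 1200 nM in an assay on HEK293 cells for negative allosteric modulation of metabotropic glutamate receptor 5 (Homo sapiens), read by FLIPR, with a stated time of 1 h; a higher number here means a weaker inhibitor, a lower number a stronger inhibitor.
Compound 2 `CC1CC(C(=O)N2CCc3nc(C#Cc4ccccc4)sc3C2)C1` reaches only the limit > 10000 nM in this assay.
Compound 3 `O=C(C1CCC(F)(F)CC1)N1CCc2nc(C#Cc3ccccc3)sc2C1` likewise reaches only the limit > 10000 nM in this assay.

All three share one core and differ only in the group on the amine nitrogen in a ring. Compound 3 therefore stands at a limit of this assay: its value is not a number, and only a ceiling on its potency is known. For the measured compounds named here, the one readable step, an at least 8.3-fold higher number from compound 1 to compound 2 (0.92 log units; beyond the scatter), shows that replacing the ethyl group with a ring amide weakens inhibition clearly. The next step, a step that the two limits leave unreadable from compound 2 to compound 3, cannot be sized because the limit of > 10000 nM in this assay, at which 2 of the 3 values shown sit, holds both compounds.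

Compound 4 `O=C(C1CCCCO1)N1CCc2nc(C#Cc3ccccc3)sc2C1` keeps the amide and changes only its ring: oxan-2-yl in place of 4,4-difluorocyclohexyl on a carbonyl carbon. Both amides measured so far sit at the limit of > 10000 nM in this assay, at which 2 of the 3 values shown sit, so compound 4, a third amide of the same kind, is expected to behave similarly. The step that the limit leaves unreadable from compound 3 to compound 4 is thus expected to show no change beyond the scatter. Compound 4 is expected to give about 15000 nM in this assay, within a range from 5000 nM to 50000 nM, most likely reported again as a limit.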

Compound 4, half-maximal inhibitory concentration: > 10000 nM
Compound 4 was reported as a limit; the forecaster's own chance of this, stated with the estimate: 75%; the middle value is on the limit's open side.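

The oxan-2-yl ring carries a hydrogen-bond acceptor where 4,4-difluorocyclohexyl has none, yet this change does not bring a readable value in this assay: compound 4 gives > 10000 nM, which is a limit and not a number. Set against the ethyl group on the ring nitrogen, the (oxan-2-yl)carbonyl group gives an at least 8.3-fold higher number from compound 1 to compound 4 (0.92 log units; beyond the scatter), so the loss seen with the first two amides now also holds for an amide whose ring contains oxygen. The steps among compounds 2, 3 and 4 cannot be read, and the three amides can only be placed together at one ceiling: the limit of > 10000 nM in this assay, at which 3 of the 4 values shown sit.

On these data alone, the true potency of these three amides stays open, so any differences among their rings remain hidden. Also open, as far as these compounds go, is whether a butyl chain or a 2-hydroxyethyl group on the ring nitrogen, in place of the ethyl group, would give a measurable number, as compound 1 does at 1200 nM.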